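Swapping chloro for methoxy on the aryl of compound 2

The source may hold more compounds than are shown below. What is called first, only, known or untested is meant among the compounds shown, and "the series" means these compounds.

Compound 1 `COc1ccc(-n2c(=O)c(C(=O)Nc3ccc(Oc4ccnc5[nH]ccc45)cc3)cc3cccnc32)cc1`: 1260 nM
Compound 2 `O=C(Nc1ccc(Oc2ccnc3[nH]ccc23)c(F)c1)c1cc2cccnc2n(-c2ccc(Cl)cc2)c1=O`: 82 nM

Of the compounds shown here, two have been measured in a functional assay on HT-29 cells (Homo sapiens) for antiproliferative activity, read by MTT assay, with a stated time of 72 h; on this read-out higher numbers stand for weaker inhibition and lower numbers for stronger inhibition. Compound 1 gives 1260 nM in this assay, and compound 2 gives 82 nM. Compound 2 thus stands at the lower of the two numbers, and the distance to compound 1 is well beyond the scatter of the method. Compounds 1 and 2 differ in more than one place, so the two values can only be set side by side, not read as one step.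

Compound 3 `COc1ccc(-n2c(=O)c(C(=O)Nc3ccc(Oc4ccnc5[nH]ccc45)c(F)c3)cc3cccnc32)cc1` is not yet measured. It differs from compound 2 in one place: methoxy in place of chloro on an aromatic carbon. Going by the values given here, the same kind of group, methoxy, is present in compound 1 alongside its weaker number, and that is the only guide the data give. A step toward a higher number is therefore expected, though its size is uncertain, and the estimate for the step of a 5.5-fold higher number from compound 2 to compound 3 (0.74 log units; beyond the scatter) is meant to be clearly beyond the scatter. Compound 3 is expected to come out at about 450 nM, with a likely range from 130 nM to 1600 nM.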

Compound 3, half-maximal inhibitory concentration: 540 nM
Compound 3: middle estimate off by 1.2-fold (0.08 log units), on the low side; low and high end bracket the measured number.
By their numbers in this assay, from the lowest: compound 2; then compound 3; then compound 1.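

Exchanging 4-chlorophenyl for 4-methoxyphenyl, on a carbon para to a large group, gives a 6.6-fold higher number from compound 2 to compound 3 (0.82 log units; beyond the scatter) in this assay, so this position responds to that change with nothing else in the structure altered. Compound 3 also provides a second single change, fluoro in place of hydrogen on an aromatic carbon, which gives a 2.3-fold lower number from compound 1 to compound 3 (0.37 log units; beyond the scatter). The distance between compound 1 and compound 2 can thus be followed through two separate changes, each beyond the scatter. No measurement at hand offers an explanation for either step.

With only chloro and methoxy at this position, the compounds shown do not tell whether other groups, such as an amine, a nitrile or a trifluoromethyl, would keep the number near that of compound 2 or move it toward that of compound 3. They also leave open whether fluoro in place of hydrogen would give a step of similar direction and size in a compound carrying 4-chlorophenyl rather than 4-methoxyphenyl.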